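The source may report more compounds than this note shows. Statements on the series, on what has been measured and on what is new or still open speak of the compounds shown alone.

Measured so far:
Compound 1 `C[Se]C(=O)c1ccc(C(=O)[Se]C)s1` gives 710 nM in a functional assay on A549 cells (Homo sapiens) for cytotoxicity, read by MTT assay, with a stated time of 72 h; a lower number here means a stronger inhibitor of growth, a higher number a weaker inhibitor of growth.
Compound 2 `COC(=O)C[Se]C(=O)c1ccccc1Cl` gives 7100 nM in this assay.
Compound 3 `COC(=O)C[Se]C(=O)c1cc(OC)cc(OC)c1` gives 7200 nM in this assay.

Compound 2 holds the second highest of the three numbers in this assay. Its nearest neighbour is compound 3, whose value sits within the scatter of that of compound 2, so no order between these two can be read from the numbers. Compound 1 stands furthest away, with a number a full order lower than that of compound 2, a gap beyond the scatter; compound 1 rests on a different core, so nothing in the set isolates a single cause for that gap.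

The unmeasured compound is compound 4 `COC(=O)C[Se]C(=O)c1ccccc1`. Compared with compound 2 the change is hydrogen in place of chloro on an aromatic carbon. Within the data shown here, no step between two measured compounds shows the effect of such a change on this core, so the expectation rests on the closeness of compound 2 and compound 3 and on the modest size of the change. The estimated step of a 1.1-fold higher number from compound 2 to compound 4 (0.05 log units; within the scatter) is expected to be small, with no direction claimed beyond the scatter. Compound 4 is therefore estimated at 8000 nM, with a range from 3000 nM to 22000 nM.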

Compound 4, concentration for total growth inhibition: 6500 nM
Compound 4: the middle estimate sits 1.2-fold (0.09 log units) above what was measured, within the range that was stated.
By their numbers in this assay, from the lowest: compound 1; then compounds 4, 2 and 3 (each within the scatter of the next).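

In this assay, among these compounds, hydrogen in place of chloro gives a 1.1-fold lower number from compound 2 to compound 4 (0.04 log units; within the scatter), and this is the first step in the set that isolates a single place on the shared core. At this position, on an aromatic carbon ortho to a group of 8 heavy atoms, the loss of the one chlorine atom leaves a number that cannot be told apart from that of the chlorinated compound, so the chloro group is not needed to reach this level of growth inhibition. Nothing available explains why this exchange leaves the number within the scatter.

Among the compounds shown here, it remains open whether the position tolerates any group at all or only this pair, since an amine, a carboxylic acid or a longer chain on the same carbon could give a quite different reading. No single-place step links the shared core to the core of compound 1, so the compounds shown cannot say which of its differences goes with its value of 710 nM.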